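Shortening the chain on the ring nitrogen of compound 2

The source may hold more compounds than are shown below. What is called first, only, known or untested is meant among the compounds shown, and "the series" means these compounds.

Of the compounds shown here, two sharing one core have been measured in a functional assay for agonist activity at follicle-stimulating hormone receptor (Homo sapiens), read by a luciferase reporter; on this read-out lower numbers stand for an effect already at smaller amounts and higher numbers for an effect only at larger amounts of compound. Compound 1, `CCCCCNC(=O)CN1CC(=O)N(C)[C@@H](Cc2ccc(-c3cccc(CN(CCCC)C(=O)NC)c3)cc2)C1=O`, gives 1.7 nM in this assay. Among the compounds with values here, compound 2, `CCCCCCCCN1CC(=O)N(C)[C@@H](Cc2ccc(-c3cc(OC)c(OC)c(OC)c3)cc2)C1=O`, gives 400 nM in this assay, the higher of the two numbers, and its gap to compound 1 lies well beyond the scatter of repeated measurements; the two differ in more than one place, so no single step connects them.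

Compound 3, `CCCCCN1CC(=O)N(C)[C@@H](Cc2ccc(-c3cc(OC)c(OC)c(OC)c3)cc2)C1=O`, keeps the core and the aryl group of compound 2 and changes only the chain on the ring nitrogen: hydrogen in place of propyl on a saturated chain carbon, five bonds along the chain from an amide-type nitrogen in a ring. The same difference, cut one bond further out, reads butyl to methyl, pentyl to ethyl, or hexyl to propyl. Within the data shown here, no measured pair shows this step on its own, and compound 1 cannot guide it, since its chain carries an amide that compound 3 lacks.

In this assay compound 3 is therefore expected to stay close to compound 2, with the step from compound 2 to compound 3 estimated at a 1.3-fold higher number from compound 2 to compound 3 (0.10 log units; within the scatter), either direction possible. The estimate for compound 3 is 500 nM, in a range from 150 nM to 2000 nM.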

Compound 3, half-maximal effective concentration: 9000 nM
The estimate for compound 3 lay 18-fold (1.26 log units) below the measured number, outside the stated range (above it).
By their numbers in this assay, from the lowest: compound 1; then compound 2; then compound 3.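

In this assay the chain on the ring nitrogen proves sensitive at its outer end: hydrogen in place of propyl, on a saturated chain carbon, five bonds along the chain from an amide-type nitrogen in a ring, gives a 23-fold higher number from compound 2 to compound 3 (1.35 log units; beyond the scatter) and counts as a large step. Within the data shown here, this is the first pair to isolate this position, and with the core and the aryl group held fixed, it shows that the octyl chain of compound 2 cannot be cut to the pentyl chain of compound 3 without a clear rise in the number. No separate measurement bears on what lies behind this rise.

Two chain lengths cannot show whether the number climbs steadily with each carbon removed or jumps at one length, a question that hexyl and heptyl chains on the ring nitrogen would address. Also open, on these data alone, are whether a decyl chain would lower the number further, whether an amine or a carboxylic acid at the end of the pentyl chain would change it, and whether the same shortening would give a similar step alongside the aryl group of compound 1.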